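The source may report more compounds than this note shows. Statements on the series, on what has been measured and on what is new or still open speak of the compounds shown alone.

Working notes on the series. Going by the values given here, compound 3 `CCOC(=O)CC1C(C(=O)OCC)=C(N)Oc2ccc(-c3ccccc3F)cc21` carries a 2-fluorophenyl group; in a functional assay on HL-60 cells (Homo sapiens) for cytotoxicity, read by CellTiter-Blue, with a stated time of 48 h (a higher number here means a weaker inhibitor, a lower number a stronger inhibitor), compound 3 gives 73000 nM, the highest of the three numbers measured so far. The other two compounds share a different aromatic substituent with each other and sit lower: compound 1 `CCOC(=O)CC1C(C(=O)OC)=C(N)Oc2ccc(-c3cc(OC)cc(OC)c3)cc21` gives 10800 nM in this assay, and compound 2 `C=CCOC(=O)CC1C(C(=O)OCC=C)=C(N)Oc2ccc(-c3cc(OC)cc(OC)c3)cc21` gives 4700 nM. Both gaps to compound 3 lie beyond the scatter, so compound 3 is the weakest inhibitor of the three.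

The next compound keeps everything else of compound 3 and changes only the aromatic substituent: compound 4 `CCOC(=O)CC1C(C(=O)OCC)=C(N)Oc2ccc(-c3cncnc3)cc21` differs from compound 3 by pyrimidin-5-yl in place of 2-fluorophenyl on an aromatic carbon. Among the compounds with values here, no measured pair in the set isolates this exchange, and the comparison of compound 1 with compound 3 also differs elsewhere in the molecule, so it gives no clean guide. On this basis a step of modest size in this assay is expected, with no firm direction, and a value within the scatter of compound 3 remains possible. For compound 4 the expected step from compound 3 is a 1.6-fold lower number from compound 3 to compound 4 (0.21 log units; within the scatter). Compound 4 is therefore estimated at 45000 nM in this assay, with a range from 12000 nM to 160000 nM.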

Compound 4, half-maximal inhibitory concentration: 37900 nM
Beside the measured number, compound 4's estimate is 1.2-fold (0.07 log units) above it, and the stated range covers the measured number.
By their numbers in this assay, from the lowest: compound 2; then compound 1; then compounds 4 and 3 (each within the scatter of the next).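

In this assay the exchange on this aromatic carbon can now be read on its own, with everything else held constant: pyrimidin-5-yl in place of 2-fluorophenyl gives a 1.9-fold lower number from compound 3 to compound 4 (0.28 log units; within the scatter) and so does not separate the two groups. At this position, a six-membered aromatic ring of carbon only with its fluorine and a six-membered aromatic ring with 2 hetero atoms and 2 hydrogen-bond acceptors read alike in this assay, so neither the loss of fluorine nor the gain of ring nitrogen registers as a real difference for this pair. Nothing measured on hand accounts for this result.

Whether the dimethoxyphenyl group of compound 1 and compound 2 would behave differently on the core of compound 3 cannot be read, since every step from those two compounds to compound 3 or compound 4 also changes the esters. From the compounds shown here alone, it also remains open whether a group of another kind on this aromatic carbon, such as an aminomethyl group or a carboxylic acid, would give a step beyond the scatter.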